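A few compounds are considered here, and "the series" means these few. Any claim that something is new, unique, unknown or untested is made for them only; others in the source may bear on it.

Series notes. Compound 1 `CNC(=O)c1cc(Oc2ccc(NC(=O)c3nn(-c4ccccc4OC(F)(F)F)c(=O)cc3C)cc2F)ccn1` and compound 2 `CNC(=O)c1cc(Oc2ccc(NC(=O)c3nn(-c4cccc(F)c4)c(=O)cc3C)cc2F)ccn1` share one core; compound 3 `Cc1cc(=O)n(-c2ccccc2OC(F)(F)F)nc1C(=O)Nc1ccc(Oc2ncnc3sccc23)cc1` and compound 4 `Cc1cc(=O)n(-c2cccc(F)c2)nc1C(=O)Nc1ccc(Oc2ncnc3sccc23)cc1` share another, and the difference between the two cores is not broken down here. In a functional assay on HepG2 cells (Homo sapiens) for cytotoxicity, read by MTT assay, with a stated time of 72 h (a higher number here means a weaker inhibitor, a lower number a stronger inhibitor), compound 1 reaches only a limit, > 40000 nM, and so sits at the limit of > 40000 nM in this assay, at which 1 of the 3 values shown sits. In this assay compound 2 gives 10200 nM. The change 3-fluorophenyl in place of 2-(trifluoromethoxy)phenyl on an aromatic nitrogen made a step of an at least 3.9-fold lower number from compound 1 to compound 2 (0.59 log units; beyond the scatter). In this assay compound 3 gives 14400 nM, which against compound 2 lies within the scatter. Compound 4 carries the same change on the second core, (3-fluorophenyl in place of 2-(trifluoromethoxy)phenyl on an aromatic nitrogen), at the same place. The step from compound 3 to compound 4 is expected to be about a 3.6-fold lower number from compound 3 to compound 4 (0.56 log units; beyond the scatter), resting on compound 1 and compound 2 with an at least 3.9-fold lower number from compound 1 to compound 2 (0.59 log units; beyond the scatter), though that earlier start is a limit. Compound 4 is therefore estimated at 4000 nM, between 1500 nM and 12000 nM.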

Compound 4, half-maximal inhibitory concentration: 18500 nM
Compound 4: the middle estimate sits 4.6-fold (0.67 log units) below what was measured; measured number outside the range, above it.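

In this assay, 3-fluorophenyl in place of 2-(trifluoromethoxy)phenyl gives a 1.3-fold higher number from compound 3 to compound 4 (0.11 log units; within the scatter), so on this core the step stays within the scatter. The step seen on the core of compound 1 did not carry over to the core of compound 3: the same change on two cores in this assay, an at least 3.9-fold lower number (0.59 log units; beyond the scatter) from compound 1 to compound 2 and a 1.3-fold higher number (0.11 log units; within the scatter) from compound 3 to compound 4, at least 5.0-fold (0.70 log units) apart, beyond the scatter of two such steps. Going by these compounds, the earlier step starts from a limit, so its true size remains unknown, and one pair on each core gives no rule for other cores: the limit of > 40000 nM in this assay, at which 1 of the 4 values shown sits.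

Still open, on these data alone, is which part of the two cores goes with the difference between the steps. Also open, as far as these compounds go, is how other groups on the aromatic nitrogen, such as unsubstituted phenyl or an aminophenyl, behave on each core.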